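The compounds below may be only part of what the source reports. "The series", "measured", "known", "first", "only" and "open" are said of these compounds alone.

Series notes. The shared core is common to all members, and the measured compounds differ only in the chain on a saturated chain carbon bound to an oxygen. Compound 1 `CCCCCC/C(=N\OCCC)c1cc(OC)c2c(c1OC)C(=O)C=CC2=O` gives 0.166 ug/mL in a functional assay on L1210 cells (Mus musculus) for antiproliferative activity; on this read-out higher numbers stand for an effect only at larger amounts of compound and lower numbers for an effect already at smaller amounts. Compound 2 `CCCCCC/C(=N\OCCCCC)c1cc(OC)c2c(c1OC)C(=O)C=CC2=O` gives 0.224 ug/mL in this assay. Compound 3 `CCCCCC/C(=N\OC)c1cc(OC)c2c(c1OC)C(=O)C=CC2=O` gives 0.192 ug/mL in this assay. On these three numbers compound 3 holds the second highest value, nearest to compound 1 and furthest from compound 2, yet all three lie within the scatter of one another, so no order among them can be read.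

Compound 4 `CCCCCCCCCO/N=C(\CCCCCC)c1cc(OC)c2c(c1OC)C(=O)C=CC2=O` follows from compound 3 by octyl in place of hydrogen on a saturated chain carbon bound to an oxygen on an unsaturated carbon. Among the compounds with values here, the steps that bear on this sit on the same carbon: a 1.2-fold higher number from compound 1 to compound 3 (0.06 log units; within the scatter), a 1.2-fold lower number from compound 2 to compound 3 (0.07 log units; within the scatter) and a 1.3-fold higher number from compound 1 to compound 2 (0.13 log units; within the scatter). None of them moved this assay beyond the scatter while the chain went from hydrogen through ethyl to butyl. Within the data shown here, the octyl chain lies well beyond that range, and no measured compound reaches it. From the measured steps the expectation for this assay is a step of no more than the scatter, with at most a slight drift to a higher number. The estimated step from compound 3 to compound 4 is a 1.3-fold higher number from compound 3 to compound 4 (0.11 log units; within the scatter). Compound 4 is thus expected to give 0.25 ug/mL in this assay, within a range from 0.1 ug/mL to 0.6 ug/mL.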

Compound 4, concentration for half-maximal effect: 1.15 ug/mL
Compound 4: the middle estimate sits 4.6-fold (0.66 log units) below what was measured; measured number above the stated range.
By their numbers in this assay, from the lowest: compounds 1, 3 and 2 (each within the scatter of the next); then compound 4.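

Within the data shown here, on the saturated chain carbon bound to an oxygen on an unsaturated carbon, octyl in place of hydrogen is the first change to leave the scatter in this assay (a 6.0-fold higher number from compound 3 to compound 4 (0.78 log units; beyond the scatter)), and the two shorter-chain comparisons point the same way (a 5.1-fold higher number from compound 2 to compound 4 (0.71 log units; beyond the scatter); a 6.9-fold higher number from compound 1 to compound 4 (0.84 log units; beyond the scatter)). This position therefore does respond to chain length: hydrogen, ethyl and butyl show no readable order among themselves, and the higher number appears only with the octyl chain, so an effect in this series now needs a larger amount of compound only at that end of the range. Nothing at hand gives a reason for this step.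

The compounds shown leave open where between butyl and octyl the change sets in, whether it builds gradually or abruptly, and whether a chain longer than octyl raises the number further. They also leave open whether a long chain ending in an amine or a carboxylic acid at this position would follow the octyl chain or stay with the shorter ones.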